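Ring amine replacements on the shared core, toward compound 4

The compounds below may be only part of what the source reports. "The series", "measured", "known", "first", "only" and "open" are said of these compounds alone.

Compound 3 `CC(C(=O)NCc1ccc(C(F)(F)F)nc1N1CCC(CN(C)C)CC1)c1ccc(NS(C)(=O)=O)c(F)c1` gives 2.1 nM in a functional assay on CHO-K1 cells for antagonist activity at transient receptor potential cation channel subfamily V member 1 (Homo sapiens), read by FLIPR (a lower number here means a stronger inhibitor, a higher number a weaker inhibitor), the lowest number of the three, while compound 2 `CC(C)OC1CCN(c2nc(C(F)(F)F)ccc2CNC(=O)C(C)c2ccc(NS(C)(=O)=O)c(F)c2)CC1` gives 3 nM, separated from it only within the scatter; compound 1 `CC(C(=O)NCc1ccc(C(F)(F)F)nc1Nc1ccc(F)cc1)c1ccc(NS(C)(=O)=O)c(F)c1` gives 39.2 nM. The steps of a 13-fold lower number from compound 1 to compound 2 (1.12 log units; beyond the scatter) and a 19-fold lower number from compound 1 to compound 3 (1.27 log units; beyond the scatter) show that a saturated ring amine in place of (4-fluorophenyl)amino on an aromatic carbon gives a large gain in this assay, whereas a 1.4-fold lower number from compound 2 to compound 3 (0.15 log units; within the scatter) shows that the group carried on that saturated ring changes little. Compound 4 `CC(C(=O)NCc1ccc(C(F)(F)F)nc1N1CCCCCCC1)c1ccc(NS(C)(=O)=O)c(F)c1` carries a group of 8 heavy atoms (7 carbon, 1 nitrogen; one eight-membered non-aromatic ring with 1 hetero atom) in place of a group of 10 heavy atoms (8 carbon, 2 nitrogen; one six-membered non-aromatic ring with 1 hetero atom), on an aromatic carbon. This keeps a saturated ring amine on the same aromatic carbon, drops the (dimethylamino)methyl group and replaces the six-membered ring by an eight-membered one; the measured steps cover the first two points but nothing addresses ring size. A small step is therefore expected, a 1.9-fold higher number from compound 3 to compound 4 (0.28 log units; within the scatter), within the scatter, with the untested ring size widening the range. Compound 4 is estimated at 4 nM in this assay, between 1.5 nM and 15 nM.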

Compound 4, inhibition constant: 0.7 nM
Compound 4: the middle estimate sits 5.7-fold (0.76 log units) above what was measured, outside the stated range (below it).
By their numbers in this assay, from the lowest: compound 4; then compounds 3 and 2 (each within the scatter of the next); then compound 1.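

The unsubstituted eight-membered ring on this aromatic carbon, next to the ring nitrogen, gives a change beyond the scatter against both six-membered ring amines in this assay: a 3.0-fold lower number from compound 3 to compound 4 (0.48 log units; beyond the scatter) and a 4.3-fold lower number from compound 2 to compound 4 (0.63 log units; beyond the scatter). Going by these compounds alone, neither the (dimethylamino)methyl group of compound 3 nor the isopropoxy group of compound 2 is therefore needed for activity at this level, and the step from the arylamine widens to a 56-fold lower number from compound 1 to compound 4 (1.75 log units; beyond the scatter) as the largest so far. Nothing available on these compounds accounts for the gain.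

Ring enlargement and loss of the ring substituent occur together in compound 4, so their separate contributions cannot be read from the compounds shown. An unsubstituted piperidin-1-yl or an azepan-1-yl at the same carbon would bear on that split, as would an isopropoxy group on the eight-membered ring.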